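Cyclopropyl in Place of Methyl on the Shared Amine

The source may hold more compounds than are shown below. What is called first, only, known or untested is meant among the compounds shown, and "the series" means these compounds.

Compound 1 `CCCNc1nc2ccccc2c(NCc2ccc(NC(=O)c3ccc(F)cc3)cc2)c1C#N`: > 20000 nM
Compound 2 `CNc1nc(NCc2ccc(C(=O)Nc3ccc(F)cc3)cc2)c2ccccc2n1`: 4100 nM
Compound 3 `CNc1nc(NCc2ccc(NC(=O)c3ccc(F)cc3)cc2)c2ccccc2n1`: 2000 nM

Of the compounds shown here, three have so far been measured in a functional assay on SW480 cells (Homo sapiens) for inhibition, read by luminescence and resazurin assay, with a stated time of 3 days; a lower number here means a stronger inhibitor, a higher number a weaker inhibitor. For compound 1 the value of > 20000 nM is a limit of the assay rather than a number. Compound 2 gives 4100 nM in this assay. Compound 3 gives 2000 nM in the same assay. Compound 2 thus stands highest of the two numbers; its nearest neighbour is compound 3, reached by a 2.1-fold lower number from compound 2 to compound 3 (0.31 log units; beyond the scatter), a modest step brought about by ((4-fluorophenyl)carbonyl)amino in place of (4-fluorophenyl)carbamoyl on an aromatic carbon.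

Compound 4 `O=C(Nc1ccc(F)cc1)c1ccc(CNc2nc(NC3CC3)nc3ccccc23)cc1` has not yet been measured. It differs from compound 2 in one place: cyclopropyl in place of methyl on a nitrogen on an aromatic ring. Among the compounds with values here, none of the measured steps touches this part of the molecule; the only measured step concerns the amide linkage and leaves the methylamino unchanged. Within the data shown here, there is therefore no measured precedent for the size or the direction of any effect of cyclopropyl in place of methyl at this nitrogen, and no step beyond the scatter is expected. In this assay compound 4 is expected to give 4000 nM, with a range from 1500 nM to 11000 nM, which means an expected step of a 1.0-fold lower number from compound 2 to compound 4 (0.01 log units; within the scatter).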

Compound 4, half-maximal inhibitory concentration: 2600 nM
Estimate against measurement, compound 4: 1.5-fold (0.19 log units) above; measured number inside the range.
By their numbers in this assay, from the lowest: compounds 3, 4 and 2 (each within the scatter of the next, the first and the last beyond it). At a limit, above all of these: compound 1.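

In this assay, within the data shown here, the methylamino to cyclopropylamino change gives the first reading at this nitrogen on an aromatic ring: a 1.6-fold lower number from compound 2 to compound 4 (0.20 log units; within the scatter). Cyclopropyl brings two more carbons and a three-membered ring of carbon only to this place, yet compound 2 and compound 4 cannot be told apart here, so this one exchange shows no real gain or loss, whereas the earlier compounds gave no reading on this nitrogen at all. Nothing in the data at hand speaks to what lies behind this result.

Going by these compounds, the reading also comes from a single pair carrying the (4-fluorophenyl)carbamoyl group, so it remains open whether cyclopropyl in place of methyl would behave the same way in compound 3, which carries ((4-fluorophenyl)carbonyl)amino instead. On these data alone, it also remains open whether a cyclobutyl ring, an isopropyl group, a longer chain or a chain ending in an amine on this nitrogen would produce a step beyond the scatter, since one exchange cannot mark how much this position accepts.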